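A Ring Swap at One Saturated Chain Carbon

The source may hold more compounds than are shown below. What is called first, only, known or untested is meant among the compounds shown, and "the series" means these compounds.

In a physicochemical assay for solubility, read by HPLC, in phosphate buffer, at pH 6.5 (on this read-out lower numbers stand for lower solubility and higher numbers for higher solubility), compound 1 `COC(=O)C1=C(C)NC(c2nccs2)=N[C@]1(C)c1ccc(F)cc1` gives 178 ug/mL and compound 2 `COC(=O)C1=C(C)NC(c2nccs2)=NC1(C)c1ccc(F)cc1Cl` gives 18 ug/mL as its reading. Compound 3 `COC(=O)C1=C(CN2CCNCC2)NC(c2nccs2)=NC1(C)c1ccc(F)cc1` gives 250 ug/mL and so sits within the usual scatter of compound 1 and clearly above compound 2. Compound 4 `COC(=O)C1=C(CN2CCC(O)C2)NC(c2nccs2)=NC1(C)c1ccc(F)cc1` is still unmeasured. It carries 3-hydroxypyrrolidin-1-yl in place of piperazin-1-yl on a saturated chain carbon bound to a double-bonded ring carbon. Among the compounds with values here, no measured pair shows this swap, so any expectation is loose. The nearest guide is compound 3 with its 250 ug/mL reading. The expected change is a 1.4-fold lower number from compound 3 to compound 4 (0.14 log units; within the scatter) and would stay within the scatter. Compound 4 is estimated at 180 ug/mL with a likely range from 70 ug/mL to 450 ug/mL in this assay once measured.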

Compound 4, solubility: 503 ug/mL
Estimate against measurement, compound 4: 2.8-fold (0.45 log units) below, outside the stated range (above it).
By their numbers in this assay, from the lowest: compound 2; then compounds 1, 3 and 4 (each within the scatter of the next, the first and the last beyond it).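

In this assay, 3-hydroxypyrrolidin-1-yl in place of piperazin-1-yl on a saturated chain carbon bound to a double-bonded ring carbon gives a 2.0-fold higher number from compound 3 to compound 4 (0.30 log units; within the scatter). At this position, then, a six-membered ring with 2 hetero atoms and a five-membered ring with 1 hetero atom give readings that cannot be told apart. Nothing measured here bears on what sets either reading. On these data alone, the hydroxyl and the ring size changed together, so their separate contributions stay open. Plain pyrrolidine or morpholine on the same chain carbon would pull these two changes apart.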